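The compounds below may be only part of what the source reports. "The series", "measured", "known", "first", "only" and "open" are said of these compounds alone.

Measured so far:
compound 1 `CC(=O)c1ccc(NC(=O)C2CC(O)CN2S(=O)(=O)c2ccc([N+](=O)[O-])cc2)cc1` — 57%
compound 2 `CC(=O)c1ccc(NC(=O)C2CCCN2S(=O)(=O)c2ccc([N+](=O)[O-])cc2)cc1` — 23.5%
compound 3 `CC(=O)c1ccc(NC(=O)CN(C(=O)c2ccccc2)S(=O)(=O)c2ccccc2)cc1` — 40.5%

In a functional assay for inhibition, read by spectrophotometry, with a stated time of 20 min, tested at 2 mg/mL (on this read-out higher numbers stand for a stronger effect at the one concentration tested and lower numbers for a weaker effect), compound 2 gives the lowest number of the three. Compound 3, the nearest, lies above it beyond the scatter, and compound 1 lies further above, also beyond the scatter. Among the compounds with values here, the only step between compounds that differ in one place is a number 33.5 percentage points lower from compound 1 to compound 2 (beyond the scatter), a large one, brought about by hydrogen in place of hydroxy on a saturated ring carbon.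

Compound 4 `CC(=O)c1ccc(NC(=O)C2CCCN2S(=O)(=O)c2ccccc2)cc1` differs from compound 2 in one place: hydrogen in place of nitro on an aromatic carbon. Within the data shown here, no measured step bears on this change. The step from compound 1 to compound 2 concerns the saturated ring and says nothing about the nitro group. Compound 3 carries a phenyl without nitro on the sulfonyl, but it differs from compound 2 in several other places as well, so its value only shows that a member of this series lacking the nitro group can stand above compound 2. Among the measured compounds shown here, with no step that isolates the nitro group, no direction can be read with confidence, and the expectation is a change not beyond the scatter, estimated as a number 3.5 percentage points higher from compound 2 to compound 4 (within the scatter). For compound 4 the estimate is 27% with a range from 8% to 48%.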

Compound 4, a percentage reported as inhibition, at one concentration (the size of the read-out at that concentration, not a potency): 25.8%
Compound 4: the middle estimate sits 1.2 percentage points above what was measured, and the stated range covers the measured number.
By their numbers in this assay, from the lowest: compounds 2 and 4 (each within the scatter of the next); then compound 3; then compound 1.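

In this assay, within the data shown here, the change from 4-nitrophenyl to phenyl, on an aromatic carbon para to a large group, gives a number 2.3 percentage points higher from compound 2 to compound 4 (within the scatter) and is the first direct reading at this position. Among these compounds, on the core of compound 2, the nitro group with its 3 heavy atoms and 2 hydrogen-bond acceptors can therefore give way to hydrogen with no step beyond the scatter, whereas the saturated ring carbon gives a number 33.5 percentage points lower from compound 1 to compound 2 (beyond the scatter) as the one large step so far. No measurement at hand offers an account of this result.

Going by these compounds, this reading belongs to the core of compound 2 alone, so what the same change does on the hydroxy-bearing core of compound 1 remains open. Also open, on these data alone, is whether another group at this aromatic carbon, such as an amine, a carboxylic acid or a methoxy group, would stand apart beyond the scatter from compound 2 and compound 4 on this read-out.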